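Switching a Linker-Free Aryl for a Benzyl Group

The source may report more compounds than this note shows. Statements on the series, on what has been measured and on what is new or still open speak of the compounds shown alone.

Three compounds share a readout from a functional assay on L1210 cells (Mus musculus) for inhibition, read by cell counting, with a stated time of 2 days; on this read-out higher numbers stand for weaker inhibition and lower numbers for stronger inhibition. Compound 1 `C=C(Br)C(=O)Nc1cccc(-c2cn3nc(-c4ccc(OCC)cc4)sc3n2)c1` gives 790 nM, the lowest of the three numbers and therefore the strongest inhibition among them. Compound 2 `Nc1cccc(-c2cn3c(-c4ccc(Cl)cc4)csc3n2)c1` gives 22000 nM in this assay, and compound 3 `Nc1cccc(-c2cn3nc(Cc4ccc(Cl)cc4)sc3n2)c1` gives 16000 nM; both gaps to compound 1 lie well beyond the usual scatter, but compound 2 and compound 3 differ from compound 1 in more than one place, so neither pair isolates a single change.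

Compound 4 `C=C(Br)C(=O)Nc1cccc(-c2cn3nc(Cc4ccc(OC)cc4)sc3n2)c1` is not yet measured. It differs from compound 1 in a single way: 4-methoxybenzyl in place of 4-ethoxyphenyl on an aromatic carbon. The same atoms are present, joined differently, so the aromatic ring now hangs from a one-carbon bridge and the chain on its oxygen is shorter. Among the measured compounds shown here, no measured pair shows this exact change, and compound 3, the only compound carrying a benzyl group, cannot be compared directly. A modest weakening is expected, roughly at the edge of the scatter, giving an expected step of a 2.0-fold higher number from compound 1 to compound 4 (0.31 log units; beyond the scatter). Compound 4 is estimated at 1600 nM, with a range from 400 nM to 6500 nM.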

Compound 4, half-maximal inhibitory concentration: 1400 nM
Compound 4: middle estimate off by 1.1-fold (0.06 log units), on the high side, and the stated range covers the measured number.
By their numbers in this assay, from the lowest: compounds 1 and 4 (each within the scatter of the next); then compounds 3 and 2 (each within the scatter of the next).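

Putting 4-methoxybenzyl in place of 4-ethoxyphenyl on this aromatic carbon gives a 1.8-fold higher number from compound 1 to compound 4 (0.25 log units; within the scatter) in this assay, so the two compounds cannot be told apart on this read-out. Among the compounds shown here, this is the first direct view of the position: with the rest of the molecule held constant, the aromatic ring can hang from a one-carbon bridge and carry a shorter chain on its oxygen without a change beyond the scatter. No supporting measurement bears on this result.

On these data alone, the bridge and the shorter chain arrive together in this one step, so the contribution of each alone remains open. Also open, as far as these compounds go, is how the position responds to a different group on the ring, such as an amine, a carboxylic acid or a propoxy chain.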